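Sulfonate ester series: amide aryl swap toward compound 4

This account rests on a few compounds, and the source may have more. Where it says the series, first, only, none or still open, it means among the compounds named here.

Three compounds of the shared core are in hand. Compound 1 `O=C(c1ccc(Cl)c(C(F)(F)F)c1)N1CCC(n2cncc2-c2ccc(OS(=O)(=O)c3cccc([N+](=O)[O-])c3)cc2)CC1` gives 249 nM in an assay on HEK293 cells for antagonist activity at P2X purinoceptor 7 (Homo sapiens), read by fluorescence, with a stated time of 2 h; on this read-out lower numbers stand for stronger inhibition and higher numbers for weaker inhibition. Compound 2 `O=C(NC1CC1)c1cccc(S(=O)(=O)Oc2ccc(-c3cncn3C3CCN(C(=O)c4ccc(Cl)c(C(F)(F)F)c4)CC3)cc2)c1` gives 88 nM in this assay, and compound 3 `O=C(c1ccc(Cl)c(C(F)(F)F)c1)N1CCC(n2cncc2-c2ccc(OS(=O)(=O)c3cccc4cnccc34)cc2)CC1` gives 45 nM in this assay. Compound 2 stands second highest of the three numbers; its nearest neighbour is compound 3, by a 2.0-fold lower number from compound 2 to compound 3 (0.29 log units; within the scatter), and the furthest is compound 1, by a 2.8-fold lower number from compound 1 to compound 2 (0.45 log units; beyond the scatter). The third measured step, a 5.5-fold lower number from compound 1 to compound 3 (0.74 log units; beyond the scatter), likewise changes only the group on the sulfonyl sulfur.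

Compound 4 `CN(C)c1ccc(C(=O)N2CCC(n3cncc3-c3ccc(OS(=O)(=O)c4cccc(C(=O)NC5CC5)c4)cc3)CC2)cc1` is not yet measured. It differs from compound 2 by 4-(dimethylamino)phenyl in place of 4-chloro-3-(trifluoromethyl)phenyl on a carbonyl carbon. For the measured compounds named here, every measured step here varies the sulfonyl aryl group; none touches the carbonyl carbon, so no measured step bears on this change, and the benzamide part has been held constant throughout. Its contribution to the number in this assay is therefore unknown from these data, and the expectation for compound 4 must be wide.

Compound 4 is expected to come out near 300 nM, within 80 nM to 1500 nM, in this assay. The step this estimate implies, a 3.4-fold higher number from compound 2 to compound 4 (0.53 log units; beyond the scatter), is expected to be a weakening of uncertain size rather than a clear gain.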

Compound 4, half-maximal inhibitory concentration: 0.49 nM
For compound 4 the middle estimate is 610-fold (2.79 log units) above the measured one; the whole stated range lies above it.
By their numbers in this assay, from the lowest: compound 4; then compounds 3 and 2 (each within the scatter of the next); then compound 1.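

In this assay the group on the carbonyl carbon proves to be the most sensitive place seen so far in this series: 4-(dimethylamino)phenyl in place of 4-chloro-3-(trifluoromethyl)phenyl gives a 180-fold lower number from compound 2 to compound 4 (2.25 log units; beyond the scatter) and so outweighs the largest step seen on the sulfonyl sulfur, a 5.5-fold lower number from compound 1 to compound 3 (0.74 log units; beyond the scatter) in the same assay. The earlier compounds shown here all kept the same benzamide part and gave no sign that this part could move the number so far, so the sulfonyl aryl group can no longer be treated as the main handle on this read-out. No evidence on hand accounts for the size of this step.

Going by these compounds, with a single pair at this position, it remains open whether the gain follows the entering dimethylamino group or the loss of the chloro and trifluoromethyl groups, a question that 4-aminophenyl, 4-methoxyphenyl or unsubstituted phenyl on the carbonyl carbon would help to separate. On these data alone, it also remains open whether the step carries over to other sulfonyl groups, such as the isoquinolin-5-yl of compound 3.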